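Fluoro for hydrogen at two different places in one series

A few compounds are considered here, and "the series" means these few. Any claim that something is new, unique, unknown or untested is made for them only; others in the source may bear on it.

Compound 1 `COc1ccc2[nH]c(-c3cn(-c4ccccc4)nc3-c3ccccc3)nc2c1` and compound 2 `COc1ccc2[nH]c(-c3cn(-c4ccccc4)nc3-c3ccc(F)cc3)nc2c1` share a core and differ only in one spot. In a functional assay on HeLa cells (Homo sapiens) for antiproliferative activity, read by MTT assay, with a stated time of 48 h (a lower number here means a stronger inhibitor, a higher number a weaker inhibitor), compound 1 gives 2870 nM, while compound 2 gives 7510 nM. The change between them is fluoro in place of hydrogen on an aromatic carbon, and its step is a 2.6-fold higher number from compound 1 to compound 2 (0.42 log units; beyond the scatter). Compound 3 `Clc1ccc(-c2nn(-c3ccccc3)cc2-c2nc3ccccc3[nH]2)cc1` has a different core; the difference between the core of compound 3 and the core of compound 1 is not broken down here. In this assay compound 3 gives 1650 nM, the lowest of the three numbers, though its gap to compound 1 lies within the scatter and only its gap to compound 2 lies beyond it.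

Compound 4 `Fc1ccc2[nH]c(-c3cn(-c4ccccc4)nc3-c3ccc(Cl)cc3)nc2c1` has not yet been measured. It differs from compound 3 by fluoro in place of hydrogen on an aromatic carbon. This is the same kind of change as that from compound 1 to compound 2, but not the same: in compound 2 the fluoro sits on a six-membered aromatic ring of carbon only, para to a large group, whereas in compound 4 it sits on a ring that is part of a fused or bridged system of two rings, meta to a fused ring and para to a fused ring. Among the compounds with values here, the only measured precedent for fluoro in place of hydrogen is the step from compound 1 to compound 2, which weakened the compound modestly. On that basis a step of a 1.8-fold higher number from compound 3 to compound 4 (0.26 log units; within the scatter) in this assay is expected, smaller than the earlier one, given the different surroundings of the place. Compound 4 is estimated at 3000 nM in this assay, with a range from 1200 nM to 8000 nM.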

Compound 4, half-maximal inhibitory concentration: 2770 nM
The estimate for compound 4 lay 1.1-fold (0.03 log units) above the measured number; the measured number falls inside the stated range.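

In this assay, fluoro in place of hydrogen on an aromatic carbon gives a 1.7-fold higher number from compound 3 to compound 4 (0.22 log units; within the scatter), so this pair cannot be told apart, while the earlier pair could. Even so, the two steps cannot be separated from each other, and the change reads alike on the two cores as far as these pairs can show: the same change on two cores in this assay, a 2.6-fold higher number (0.42 log units; beyond the scatter) from compound 1 to compound 2 and a 1.7-fold higher number (0.22 log units; within the scatter) from compound 3 to compound 4, 1.6-fold (0.19 log units) apart, within the scatter of two such steps. This is no more than a lack of conflict between two pairs, not proof that the change carries over from one core to another, since the fluoro stands at a different place in each pair and the effect of the place cannot be separated from that of the core.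

Still open, on these data alone, is what fluoro in place of hydrogen does when the place is held constant across both cores, which would separate the core from the place. Also open, as far as these compounds go, is how groups other than fluoro would read at the place on a six-membered aromatic ring of carbon only that is part of a fused or bridged system of two rings, such as an amine, a carboxylic acid or a longer chain, in this assay.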